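This account rests on a few compounds, and the source may have more. Where it says the series, first, only, none or still open, it means among the compounds named here.

In an ADME assay on CHO-K1 cells (Cricetulus griseus) for cytotoxicity, read by MTT assay, with a stated time of 24 h (on this read-out higher numbers stand for lower toxicity in this test and lower numbers for higher toxicity in this test), compound 1 `Oc1ccc(NC(=S)Nc2ccc3[nH]ccc3c2)cc1` gives 848000 nM and compound 2 `S=C(Nc1ccc(Br)cc1)Nc1ccc2[nH]ccc2c1` gives 220000 nM, the lower of the two numbers. Compound 3 `CC(=O)c1ccc(NC(=S)Nc2ccc3[nH]ccc3c2)cc1` carries acetyl in place of bromo on an aromatic carbon, para to a large group: acetyl in place of bromo on an aromatic carbon. For the measured compounds named here, only one measured step bears on this change, the modest 3.9-fold lower number from compound 1 to compound 2 (0.59 log units; beyond the scatter), which swapped hydroxy for bromo at that same place. Going by the values given here, no acetyl compound has yet been measured, so this step is a guide to size only. Among the compounds with values here, with compound 2 at the low end at 220000 nM and that modest step as the sole measure of change here, a small move in this assay towards a higher number is expected, possibly none beyond the scatter. The expected change is a 1.8-fold higher number from compound 2 to compound 3 (0.26 log units; within the scatter). For compound 3 the estimated value is 400000 nM, with an expected range of 130000 nM to 1000000 nM.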

Compound 3, concentration lethal to 50% of the cells: 154000 nM
Estimate against measurement, compound 3: 2.6-fold (0.41 log units) above, within the range that was stated.
By their numbers in this assay, from the lowest: compounds 3 and 2 (each within the scatter of the next); then compound 1.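

In this assay, acetyl in place of bromo on an aromatic carbon shows a 1.4-fold lower number from compound 2 to compound 3 (0.15 log units; within the scatter) and so does not separate the two groups, although acetyl brings a hydrogen-bond acceptor and a double bond outside aromatic rings that bromo lacks. Acetyl in place of hydroxy shows a 5.5-fold lower number from compound 1 to compound 3 (0.74 log units; beyond the scatter) and runs the same way as the earlier bromo step, so two different replacements now part from hydroxy at this place, and of these three groups hydroxy alone stands apart. Nothing at hand explains this result.

From the compounds shown here alone, whether the higher number belongs to hydroxy alone, or would also come with an amine or a carboxylic acid at this place, stays open. So does whether hydroxy gives the same number elsewhere on the ring.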